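Swapping Furan for Bromophenyl in a Vero Cytotoxicity Series

This account rests on a few compounds, and the source may have more. Where it says the series, first, only, none or still open, it means among the compounds named here.

Measured so far in an ADME assay on Vero cells (Chlorocebus sabaeus) for cytotoxicity, read by resazurin assay, with a stated time of 3 days; a lower number here means a stronger inhibitor, a higher number a weaker inhibitor:
Compound 1 `CN(C)c1cc2[nH]c(C3CCCCC3)nc2cc1NC(=O)OCc1ccccc1` gives only a limit of the assay, > 100 ug/mL.
Compound 2 `Cc1ccc(C(=O)Nc2cc3nc(C4CCCCC4)[nH]c3cc2N2CCCC2)cc1` gives only a limit of the assay, > 100 ug/mL.
Compound 3 `CN(C)c1cc2[nH]c(C3CCCCC3)nc2cc1NC(=O)c1ccco1` gives only a limit of the assay, > 100 ug/mL.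

Compound 3 therefore stands where every measured value sits, at the limit (the limit of > 100 ug/mL in this assay, at which 3 of the 3 values shown sit), with no number beyond it. The next compound, compound 4 `CN(C)c1cc2[nH]c(C3CCCCC3)nc2cc1NC(=O)c1ccc(Br)cc1`, differs from compound 3 by 4-bromophenyl in place of furan-2-yl on a carbonyl carbon. Among the measured compounds shown here, the one measured change on the same carbonyl carbon, a step that the two limits leave unreadable from compound 1 to compound 3, is left unreadable by the two limits, so no measured step gives a size or a direction. With all three values at the limit, no shift beyond the scatter is expected in this assay, and the step that the limit leaves unreadable from compound 3 to compound 4 is estimated accordingly. Compound 4 is expected to give about 150 ug/mL, within 60 ug/mL to 400 ug/mL.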

Compound 4, half-maximal inhibitory concentration: > 100 ug/mL
Compound 4 gave a limit, no number (the forecaster's own chance of this, stated with the estimate: 85%); the middle value is on the limit's open side.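

The steps from compound 3 and from compound 1 to compound 4 cannot be read, since each compares one limit with another: the limit of > 100 ug/mL in this assay, at which 4 of the 4 values shown sit.

Whether 4-bromophenyl in place of furan-2-yl changes the result in this assay at all stays open, as does how far beyond the limit any of these compounds lies.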